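A few compounds are considered here, and "the series" means these few. Any claim that something is new, unique, unknown or untested is made for them only; others in the source may bear on it.

Measured so far:
Compound 1, `CC(C)c1ccc(C[C@H]2COc3cc(-c4cc(F)ccc4C(=O)O)ccc3[C@@H]2O)cc1`: 210 nM
Compound 2, `NS(=O)(=O)c1ccc(F)cc1-c1ccc2c(c1)OC[C@H](Cc1ccccc1)[C@H]2O`: 17 nM

Both were tested in a functional assay with leukotriene B4 receptor (Homo sapiens) as the target; on this read-out lower numbers stand for stronger inhibition and higher numbers for weaker inhibition. Compound 1 gives 210 nM, the higher of the two numbers. Compound 2 gives 17 nM, and the gap between the two values lies beyond the scatter. Compound 2 differs from compound 1 in more than one place, so none of that gap can be tied to a single change.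

Compound 3, `O=C(O)c1ccc(F)cc1-c1ccc2c(c1)OC[C@H](Cc1ccc(C(F)(F)F)cc1)[C@H]2O`, has not been measured. It keeps the core of compound 1 and alters one group: trifluoromethyl in place of isopropyl on an aromatic carbon. Going by the values given here, no measured pair shows what this swap does on its own, so the expectation rests on compound 1 alone. Only a small step is expected, the estimated change from compound 1 to compound 3 being a 1.4-fold lower number from compound 1 to compound 3 (0.15 log units; within the scatter), not clearly beyond the scatter. Compound 3 is therefore expected to give about 150 nM, within a range of 50 nM to 500 nM.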

Compound 3, half-maximal inhibitory concentration: 1800 nM
Estimate against measurement, compound 3: 12-fold (1.08 log units) below; measured number outside the range, above it.
By their numbers in this assay, from the lowest: compound 2; then compound 1; then compound 3.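

In this assay, trifluoromethyl in place of isopropyl on an aromatic carbon gives an 8.6-fold higher number from compound 1 to compound 3 (0.93 log units; beyond the scatter), so this position is sensitive to which group it carries. Neither group has a ring, a hydrogen-bond donor or acceptor, or a net charge, so those counted features do not separate them, yet the number still rises well beyond the scatter. No measurement shown here explains this rise.

As far as these compounds go, only these two groups can be compared directly at this position, so it remains open how others, such as a methoxy group, an amine or a longer chain, would fare there. It is also unknown whether the same swap would have a similar effect on the core of compound 2.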